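Nitro to chloro on the nitrophenyl imidazole series

A few compounds are considered here, and "the series" means these few. Any claim that something is new, unique, unknown or untested is made for them only; others in the source may bear on it.

Measured so far in an ADME assay on L6 cells (Rattus norvegicus) for cytotoxicity, read by fluorescence and resazurin assay, with a stated time of 72 h; on this read-out higher numbers stand for lower toxicity in this test and lower numbers for higher toxicity in this test:
- compound 1 `Clc1ccc(C(c2c[nH]cc2-c2ccc3ccccc3c2)n2ccnc2)c(Cl)c1`: 6540 nM
- compound 2 `O=[N+]([O-])c1ccc(-n2ccc(C(c3ccccc3)n3ccnc3)c2)cc1`: 60400 nM
- compound 3 `O=[N+]([O-])c1ccc(C(c2ccn(-c3ccc([N+](=O)[O-])cc3)c2)n2ccnc2)cc1`: 159000 nM

Compound 3 gives the highest number of the three in this assay. Compound 2 lies nearest to it and compound 1 furthest from it.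

The next compound is compound 4 `O=[N+]([O-])c1ccc(-n2ccc(C(c3ccc(Cl)cc3)n3ccnc3)c2)cc1`, which has chloro in place of nitro on an aromatic carbon of compound 3 (chloro in place of nitro on an aromatic carbon).

Going by the values given here, one measured step bears directly on this place. Compound 2 carries hydrogen there, and nitro in place of that hydrogen gives a 2.6-fold higher number from compound 2 to compound 3 (0.42 log units; beyond the scatter). Among the compounds with values here, no measured step shows chloro at this place. Compound 1 6540 nM does bear chloro groups, but it differs from compound 3 in more than one place and gives no clean comparison.

Removing the nitro group is therefore expected to give back at least the modest rise seen in the step from hydrogen, with a lower number in this assay. The expected change is a 3.5-fold lower number from compound 3 to compound 4 (0.55 log units; beyond the scatter), probably beyond the scatter but not by a wide margin.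

For compound 4 the estimated value is 45000 nM, with an expected range from 15000 nM to 130000 nM.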

Compound 4, half-maximal cytotoxic concentration: 82400 nM
Compound 4: middle estimate off by 1.8-fold (0.26 log units), on the low side; the range from low to high includes it.
By their numbers in this assay, from the lowest: compound 1; then compounds 2, 4 and 3 (each within the scatter of the next, the first and the last beyond it).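

In this assay, compound 4 gives the first direct read of chloro on this aromatic carbon, para to a large group, and the swap from nitro to chloro does not separate the two groups (a 1.9-fold lower number from compound 3 to compound 4 (0.29 log units; within the scatter)). Chloro in place of hydrogen does not separate those two groups either (a 1.4-fold higher number from compound 2 to compound 4 (0.13 log units; within the scatter)), so the only step at this position beyond the scatter remains the one from hydrogen to nitro (a 2.6-fold higher number from compound 2 to compound 3 (0.42 log units; beyond the scatter)), with chloro within the scatter of both. The position therefore tolerates all three substituents with only a small spread in this read-out, and no measurement at hand offers an explanation for that spread.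

Still open, going by these compounds, is whether an amine, a carboxylic acid or a methoxy group at this position would move the number further than chloro does, or would stay within the same narrow band. Also open is how much the 4-nitrophenyl group kept by compound 2, compound 3 and compound 4 contributes to the read-out, since no step among these compounds changes that group alone.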